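Silicon substituent swap in a squalene monooxygenase series

The source may report more compounds than this note shows. Statements on the series, on what has been measured and on what is new or still open speak of the compounds shown alone.

Compound 2 `CCN(C/C=C/C#CC(C)(C)C)Cc1cccc(OC[Si](C)(C)c2ccc(C=O)cc2)c1` gives 100 nM in a functional assay on liver (Sus scrofa) for inhibition of squalene monooxygenase (Homo sapiens), using microsomes (a lower number here means a stronger inhibitor, a higher number a weaker inhibitor), the highest of the two numbers shown, while compound 1 `CCN(C/C=C/C#CC(C)(C)C)Cc1cccc(OC[Si](C)(C)c2ccccc2C(F)(F)F)c1` sits nearest at 70 nM. Going by the values given here, the only measured step at the silicon, a 1.4-fold higher number from compound 1 to compound 2 (0.15 log units; within the scatter), lies within the scatter. Compound 3 `CCN(C/C=C/C#CC(C)(C)C)Cc1cccc(OC[Si](C)(C)Cc2ccccc2)c1` differs from compound 2 by benzyl in place of 4-formylphenyl on a silicon. That single step is the one that bears on this change, and it was flat, so no step beyond the scatter is expected in this assay for compound 3, which is estimated at 100 nM with a range of 40 nM to 250 nM. The expected step is no change at the digits printed from compound 2 to compound 3 (within the scatter).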

Compound 3, half-maximal inhibitory concentration: 130 nM
For compound 3 the middle estimate is 1.3-fold (0.11 log units) below the measured one; measured number inside the range.
By their numbers in this assay, from the lowest: compounds 1, 2 and 3 (each within the scatter of the next).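

With benzyl on the silicon, the ring-bearing group now includes a form with no hydrogen-bond acceptor, and this assay shows a 1.3-fold higher number from compound 2 to compound 3 (0.11 log units; within the scatter) and a 1.9-fold higher number from compound 1 to compound 3 (0.27 log units; within the scatter). Across the three groups tried at this silicon, the numbers therefore stay within the scatter, whether the group is 2-(trifluoromethyl)phenyl, 4-formylphenyl or benzyl. No measurement here accounts for this flatness. Still open, on these data alone, is whether the silicon holds this level with a group lacking a ring, such as a longer chain, or with a ring carrying an amine or a carboxylic acid.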